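The compounds below may be only part of what the source reports. "The series", "measured", "known", "first", "only" and "open" are said of these compounds alone.

Compound 1 `CC(O)Cn1nnnc1-c1ccccc1-c1ccc(CN2C(=O)[C@H](NC(=O)CC(C)(C)N)CCc3ccccc32)cc1`: 0.05 uM; compound 2 `CC(C)(N)CC(=O)N[C@@H]1CCc2ccccc2N(Cc2ccc(-c3ccccc3C(=O)O)cc2)C1=O`: 3 uM; compound 3 `CC(C)(N)CC(=O)N[C@@H]1CCc2ccccc2N(Cc2ccc(-c3ccccc3-c3nnn(Cc4ccccc4)n3)cc2)C1=O`: 1 uM.

In a functional assay (Pituitary gland cell) with Rattus norvegicus as the target (on this read-out higher numbers stand for an effect only at larger amounts of compound and lower numbers for an effect already at smaller amounts), compound 3 holds the second-highest number of the three: compound 2 is nearest, through the step of a 3.0-fold lower number from compound 2 to compound 3 (0.48 log units; beyond the scatter), and compound 1 is furthest, through the step of a 20-fold higher number from compound 1 to compound 3 (1.30 log units; beyond the scatter). Compound 4 `CC(O)Cn1nnc(-c2ccccc2-c2ccc(CN3C(=O)[C@H](NC(=O)CC(C)(C)N)CCc4ccccc43)cc2)n1` differs from compound 3 by 1-hydroxyethyl in place of phenyl on a saturated chain carbon bound to an aromatic nitrogen. The step of a 20-fold higher number from compound 1 to compound 3 (1.30 log units; beyond the scatter) bears on this most: compound 1 carries a 1-(2-hydroxypropyl)-1H-tetrazol-5-yl group, so that step ran the benzyl-to-hydroxypropyl exchange backwards while also moving the arm on the tetrazole. The step of a 60-fold higher number from compound 1 to compound 2 (1.78 log units; beyond the scatter) shows how strongly this part of the molecule weighs. For compound 4 a large step toward lower numbers is expected, a 6.7-fold lower number from compound 3 to compound 4 (0.82 log units; beyond the scatter). Compound 4 is estimated at 0.15 uM, between 0.04 uM and 0.6 uM.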

Compound 4, concentration for half-maximal effect: 0.05 uM
Estimate against measurement, compound 4: 3.0-fold (0.48 log units) above, and the stated range covers the measured number.
By their numbers in this assay, from the lowest: compounds 1 and 4 (each within the scatter of the next); then compound 3; then compound 2.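

In this assay, exchanging benzyl for 2-hydroxypropyl while the arm stays on the same tetrazole nitrogen gives a large step on its own (a 20-fold lower number from compound 3 to compound 4 (1.30 log units; beyond the scatter)), and the new group also stands far from carboxy (a 60-fold lower number from compound 2 to compound 4 (1.78 log units; beyond the scatter)). Moving the 2-hydroxypropyl arm between the two tetrazole forms does not register (no change at the digits printed from compound 1 to compound 4 (within the scatter)), so the earlier gap between compound 1 and compound 3 follows the arm's identity rather than its place. No data shown explain these steps. On these data alone, the change removes a phenyl ring and adds a hydroxyl at once, so the role of the hydroxyl stays open. A plain propyl chain, or an amine in place of the hydroxyl, would separate the two.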